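Shifting the Fluorine on the Anilide Ring of Compound 3

The source may hold more compounds than are shown below. What is called first, only, known or untested is meant among the compounds shown, and "the series" means these compounds.

Compound 3 `Cc1cccc(F)c1N(C)C(=O)c1ccc(-c2ccc(O)cc2)o1` gives 120 nM in an assay on T47D cells for inhibition of 17-beta-hydroxysteroid dehydrogenase type 1 (Homo sapiens), read by HPLC, with a stated time of 24 h (on this read-out lower numbers stand for stronger inhibition and higher numbers for weaker inhibition), the highest number among the three measured compounds. Compound 1 `Cc1ccccc1N(C)C(=O)c1ccc(-c2cccc(O)c2)o1` gives 29 nM and compound 2 `Cc1ccccc1N(C)C(=O)c1ccc(-c2ccc(O)c(F)c2)o1` gives 10 nM, and both of those gaps to compound 3 lie beyond the scatter. Among the compounds with values here, the only step between measured compounds that differ in one place, a 2.9-fold lower number from compound 1 to compound 2 (0.46 log units; beyond the scatter), concerns the phenol-bearing ring and not the ring on the amide nitrogen. Compound 4 `Cc1c(F)cccc1N(C)C(=O)c1ccc(-c2ccc(O)cc2)o1` differs from compound 3 only in that ring: 3-fluoro-2-methylphenyl in place of 2-fluoro-6-methylphenyl on an amide-type nitrogen. Within the data shown here, no measured pair shows what rearranging the fluorine and methyl within this ring does, and compound 1 differs from compound 3 in both rings at once, so it offers no clean reference. With nothing bearing on the change directly, the expectation is a step of no settled direction, within or near the scatter, a 1.3-fold lower number from compound 3 to compound 4 (0.12 log units; within the scatter). Compound 4 is therefore expected to give 90 nM in this assay, with a range from 25 nM to 320 nM.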

Compound 4, half-maximal inhibitory concentration: 50 nM
The estimate for compound 4 lay 1.8-fold (0.26 log units) above the measured number; the range from low to high includes it.
By their numbers in this assay, from the lowest: compound 2; then compounds 1 and 4 (each within the scatter of the next); then compound 3.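

In this assay, the ring on the amide-type nitrogen proves able to move the number on its own: with the rest of the structure unchanged, 3-fluoro-2-methylphenyl in place of 2-fluoro-6-methylphenyl gives a 2.4-fold lower number from compound 3 to compound 4 (0.38 log units; beyond the scatter). Within the data shown here, the two groups hold the same atoms, so this modest step comes from rearrangement alone, something the earlier compounds could not show, as their only step lay in the phenol-bearing ring. Nothing at hand explains the step.

The compounds shown leave open whether this step would hold with the phenol-bearing ring of compound 2 in place of that of compound 4. They also leave open how a chlorine, a methoxy group or an amine would read in place of the fluorine on this ring.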